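A few compounds are considered here, and "the series" means these few. Any claim that something is new, unique, unknown or untested is made for them only; others in the source may bear on it.

Three measured compounds share one core, a substituted phenyl ring on a piperazine attached through a thiosemicarbazone to an oxindole bearing chlorine. Compound 1 `O=C1Nc2ccc(Cl)cc2/C1=N/NC(=S)N1CCN(c2ccccc2)CC1` gives 7340 nM in a functional assay on A549 cells (Homo sapiens) for inhibition, read by MTT assay, with a stated time of 72 h; on this read-out lower numbers stand for stronger inhibition and higher numbers for weaker inhibition. Compound 2 `Cc1ccccc1N1CCN(C(=S)N/N=C2\C(=O)Nc3ccc(Cl)cc32)CC1` gives 6520 nM in this assay, and compound 3 `O=C1Nc2ccc(Cl)cc2/C1=N/NC(=S)N1CCN(c2ccccc2F)CC1` gives 10500 nM. Compound 3 holds the highest of the three numbers, yet both gaps stay within the scatter. Compound 4 `O=C1Nc2ccc(Cl)cc2/C1=N/NC(=S)N1CCN(c2ccccc2[N+](=O)[O-])CC1` differs from compound 3 by nitro in place of fluoro on an aromatic carbon. Among the measured compounds shown here, the steps that bear on this ring position are a 1.1-fold lower number from compound 1 to compound 2 (0.05 log units; within the scatter), a 1.4-fold higher number from compound 1 to compound 3 (0.16 log units; within the scatter) and a 1.6-fold higher number from compound 2 to compound 3 (0.21 log units; within the scatter), none of them beyond the scatter, so another small change here is expected to move the number little in either direction. Compound 4 is therefore estimated at 9000 nM, between 3500 nM and 25000 nM, an expected step of a 1.2-fold lower number from compound 3 to compound 4 (0.07 log units; within the scatter).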

Compound 4, half-maximal inhibitory concentration: 5580 nM
For compound 4 the middle estimate is 1.6-fold (0.21 log units) above the measured one; the measured number falls inside the stated range.
By their numbers in this assay, from the lowest: compounds 4, 2, 1 and 3 (each within the scatter of the next).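

Nitro is a larger group than fluoro and adds hydrogen-bond acceptors at this place, ortho to a large group, yet in this assay the step stays within the scatter when it replaces fluoro (a 1.9-fold lower number from compound 3 to compound 4 (0.27 log units; within the scatter)), methyl (a 1.2-fold lower number from compound 2 to compound 4 (0.07 log units; within the scatter)) or hydrogen (a 1.3-fold lower number from compound 1 to compound 4 (0.12 log units; within the scatter)). Among the compounds shown here, no single step therefore separates any of these four groups at this position. No available evidence explains this flat result.

On these data alone, whether an amine, a carboxylic acid or a longer chain here would produce a step beyond the scatter remains open. So does whether nitro would behave the same way elsewhere on the ring.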